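Ortho-halogen swap on the arylpiperazine of compound 1

The source may report more compounds than this note shows. Statements on the series, on what has been measured and on what is new or still open speak of the compounds shown alone.

Measured compounds in an assay on CHO cells for displacement of a labelled ligand from adenosine receptor A2b (Homo sapiens), read by scintillation counting, with a stated time of 75 min, in the presence of a further agent that is not named here; on this read-out higher numbers stand for weaker inhibition and lower numbers for stronger inhibition:
- compound 1, `CCCn1c(=O)[nH]c2nc(-c3ccc(S(=O)(=O)N4CCN(c5ccccc5Cl)CC4)cc3)[nH]c2c1=O`: 0.403 nM
- compound 2, `CCCn1c(=O)[nH]c2nc(-c3ccc(S(=O)(=O)N4CCN(c5ccc(Cl)cc5F)CC4)cc3)[nH]c2c1=O`: 1.91 nM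
- compound 3, `CCCn1c(=O)[nH]c2nc(-c3ccc(S(=O)(=O)N4CCN(C(C)c5ccccc5)CC4)cc3)[nH]c2c1=O`: 8.34 nM

Compound 1 gives the lowest number of the three. The step of a 4.7-fold higher number from compound 1 to compound 2 (0.68 log units; beyond the scatter) is modest; the step of a 21-fold higher number from compound 1 to compound 3 (1.32 log units; beyond the scatter) is large. Both steps change the whole group on the amine nitrogen in the ring, and neither is a halogen-for-halogen swap.

Compound 4, `CCCn1c(=O)[nH]c2nc(-c3ccc(S(=O)(=O)N4CCN(c5ccccc5F)CC4)cc3)[nH]c2c1=O`, differs from compound 1 by fluoro in place of chloro on an aromatic carbon. Among the measured compounds shown here, no measured step isolates this exchange; the nearest guide is compound 2, where a chloro remains on the ring and a fluoro ortho to a large group is added, yet the number rises only modestly. A step within the scatter, or a small loss, is therefore expected for compound 4: a 1.7-fold higher number from compound 1 to compound 4 (0.24 log units; within the scatter). Compound 4 is estimated at 0.7 nM in this assay, with a range of 0.3 nM to 1.8 nM.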

Compound 4, inhibition constant: 3.22 nM
Beside the measured number, compound 4's estimate is 4.6-fold (0.66 log units) below it, outside the stated range (above it).
By their numbers in this assay, from the lowest: compound 1; then compounds 2 and 4 (each within the scatter of the next); then compound 3.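

In this assay, fluoro and chloro are not interchangeable on this aromatic carbon ortho to a large group: the exchange costs more than the scatter (an 8.0-fold higher number from compound 1 to compound 4 (0.90 log units; beyond the scatter)), so the result here depends on which halogen is present. A second chloro position on the fluoro ring gives no readable change (a 1.7-fold higher number from compound 2 to compound 4 (0.23 log units; within the scatter)), while 2-fluorophenyl still keeps an edge over 1-phenylethyl (a 2.6-fold lower number from compound 3 to compound 4 (0.41 log units; beyond the scatter)). The data offer no explanation for the chloro preference. As far as these compounds go, whether bromo or methyl at this position would match chloro stays open. So does the effect of a methoxy there.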